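This account rests on a few compounds, and the source may have more. Where it says the series, first, only, none or still open, it means among the compounds named here.

Compound 1 `CCCN(CC[C@H]1CC[C@H](NS(=O)(=O)c2cccc(Cl)c2)CC1)[C@H]1CCc2nc(N)sc2C1`: 1.1 nM
Compound 2 `CCCN(CC[C@H]1CC[C@H](NS(=O)(=O)c2ccccc2Cl)CC1)[C@H]1CCc2nc(N)sc2C1`: 0.68 nM
Compound 3 `CCCN(CC[C@H]1CC[C@H](NS(=O)(=O)c2ccc(C(C)C)cc2)CC1)[C@H]1CCc2nc(N)sc2C1`: 4.5 nM

In an assay on brain for displacement of a labelled ligand from D(3) dopamine receptor (Rattus norvegicus) (on this read-out lower numbers stand for stronger inhibition and higher numbers for weaker inhibition), compound 3 gives the highest of the three numbers: the step of a 4.1-fold higher number from compound 1 to compound 3 (0.61 log units; beyond the scatter) and the step of a 6.6-fold higher number from compound 2 to compound 3 (0.82 log units; beyond the scatter) both lie beyond the scatter. Compound 4 `CCCN(CC[C@H]1CC[C@H](NS(=O)(=O)c2ccc(C(C)(C)C)cc2)CC1)[C@H]1CCc2nc(N)sc2C1` differs from compound 3 by methyl in place of hydrogen on a saturated chain carbon bound to an aromatic carbon and two saturated chain carbons. Within the data shown here, no measured pair shows a change of this kind, so none of the three steps bears on it directly; those two steps only show that 4-isopropylphenyl went with higher numbers than either chlorophenyl. A step of a 1.4-fold higher number from compound 3 to compound 4 (0.16 log units; within the scatter) is therefore expected, small and possibly within the scatter, toward a slightly higher number. Compound 4 is estimated at 6.5 nM, with a range from 2.2 nM to 20 nM.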

Compound 4, inhibition constant: 5 nM
Beside the measured number, compound 4's estimate is 1.3-fold (0.11 log units) above it, and the stated range covers the measured number.
By their numbers in this assay, from the lowest: compounds 2 and 1 (each within the scatter of the next); then compounds 3 and 4 (each within the scatter of the next).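

In this assay, methyl in place of hydrogen on this saturated chain carbon changes nothing that can be read, with a 1.1-fold higher number from compound 3 to compound 4 (0.05 log units; within the scatter). The 4-(tert-butyl)phenyl group stays as clearly apart from the chlorophenyl groups as 4-isopropylphenyl did, with a 7.4-fold higher number from compound 2 to compound 4 (0.87 log units; beyond the scatter) and a 4.5-fold higher number from compound 1 to compound 4 (0.66 log units; beyond the scatter). Nothing measured here explains these numbers.

Open, going by these compounds, is whether the gap follows the place on the ring or the group itself, which 4-chlorophenyl could separate. Also open, on these data alone, is how 4-methoxyphenyl or 4-aminophenyl would compare.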